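The compounds below may be only part of what the source reports. "The series", "measured", "known", "first", "only" and "open" are said of these compounds alone.

In a functional assay on SW-620 cells (Homo sapiens) (a higher number here means a weaker inhibitor of growth, a lower number a stronger inhibitor of growth), compound 1 `O=S(=O)(/C=C/c1ccc(F)cc1)Cc1ccc(Nc2ncnc3ccccc23)cc1` gives 100000 nM. Compound 2 `N#Cc1ccc(/C=C/S(=O)(=O)Cc2ccc(Nc3ncnc4ccccc34)cc2)cc1` is reported only as a limit, > 100000 nM. Compound 3 `O=S(=O)(/C=C/c1ccc(Br)cc1)Cc1ccc(Nc2ncnc3ccccc23)cc1` is likewise reported only as a limit, > 100000 nM. Two compounds share that ceiling: the limit of > 100000 nM in this assay, at which 2 of the 3 values shown sit. Compound 3 therefore has no exact number. Compound 4 `O=S(=O)(/C=C/c1ccc(Cl)cc1)Cc1ccc(Nc2ncnc3ccccc23)cc1` differs from it by one swap, chloro in place of bromo on an aromatic carbon. Three measured steps change this same ring substituent: a number no lower from compound 1 to compound 3 (the limit leaves the size open), a number no lower from compound 1 to compound 2 (the limit leaves the size open) and a step that the two limits leave unreadable from compound 2 to compound 3. The limits leave the size of all three open, and none shows a lower number. No change beyond the scatter is therefore expected, and the estimated step is a number no higher from compound 3 to compound 4 (the limit leaves the size open). Compound 4 is expected near 100000 nM, with an estimated range of 40000 nM to 100000 nM.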

Compound 4, concentration for 50% growth inhibition: 77000 nM
The estimate for compound 4 lay 1.3-fold (0.11 log units) above the measured number; the range from low to high includes it.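

In this assay, fluoro and chloro at this position cannot be told apart: a 1.3-fold lower number from compound 1 to compound 4 (0.11 log units; within the scatter). Against the other two compounds, there are only floors, an at least 1.2-fold lower number from compound 3 to compound 4 (0.11 log units; that floor lies within the scatter) and an at least 1.2-fold lower number from compound 2 to compound 4 (0.11 log units; that floor lies within the scatter), and the true size of each step stays open: the limit of > 100000 nM in this assay, at which 2 of the 4 values shown sit. Compound 4 thus adds a second exact number to this series, and that number stays close to compound 1's.

On these data alone, whether an amine or a carboxylic acid at this position would give a clearly lower number remains open. So does the effect of any change elsewhere in the shared core.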